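Trisubstituted sulfanyl series: a carbonyl to carbamoyl step

The source may hold more compounds than are shown below. What is called first, only, known or untested is meant among the compounds shown, and "the series" means these compounds.

Measured so far in a functional assay on PC-3 cells (Homo sapiens) for inhibition, read by MTT assay, with a stated time of 48 h; on this read-out lower numbers stand for stronger inhibition and higher numbers for weaker inhibition:
compound 1 `CCSc1nnc(-c2cc(OC)c(OC)c(OC)c2)n1-c1ccc(OC)cc1` gives 57700 nM
compound 2 `COc1ccc(-n2c(SCc3ccccc3)nnc2-c2cc(OC)c(OC)c(OC)c2)cc1` gives 34100 nM
compound 3 `COc1ccc(-n2c(SCC(=O)c3ccc(F)cc3)nnc2-c2cc(OC)c(OC)c(OC)c2)cc1` gives 58300 nM

All three carry the same core and differ only in the group on the saturated chain carbon bound to the sulfur. Compound 3 sits within the scatter of both others: the step of a 1.0-fold higher number from compound 1 to compound 3 (0.00 log units; within the scatter) is flat, and the step of a 1.7-fold higher number from compound 2 to compound 3 (0.23 log units; within the scatter) is small. None of the three can be separated from the others on this read-out.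

Compound 4 `COc1ccc(-n2c(SCC(=O)Nc3ccc(Cl)cc3)nnc2-c2cc(OC)c(OC)c(OC)c2)cc1` is not yet measured. It differs from compound 3 by (4-chlorophenyl)amino in place of 4-fluorophenyl on a carbonyl carbon. Among the compounds with values here, no measured step touches the carbonyl carbon itself; the steps that exist all replace the whole group on the saturated chain carbon bound to the sulfur, and each of them, a 1.7-fold lower number from compound 1 to compound 2 (0.23 log units; within the scatter), a 1.0-fold higher number from compound 1 to compound 3 (0.00 log units; within the scatter) and a 1.7-fold higher number from compound 2 to compound 3 (0.23 log units; within the scatter), stays within the scatter. The change from (4-fluorophenyl)carbonyl to (4-chlorophenyl)carbamoyl is of a similar kind, a substituent swap at the far end of that chain, so no step beyond the scatter is expected in this assay, in either direction.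

Compound 4 is therefore estimated at 45000 nM, with a range of 15000 nM to 120000 nM, an expected step of a 1.3-fold lower number from compound 3 to compound 4 (0.11 log units; within the scatter) that stays within the scatter.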

Compound 4, half-maximal inhibitory concentration: 6290 nM
Beside the measured number, compound 4's estimate is 7.2-fold (0.85 log units) above it, and the stated range ends above it.
By their numbers in this assay, from the lowest: compound 4; then compounds 2, 1 and 3 (each within the scatter of the next).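

In this assay, within the data shown here, the far end of the chain on the sulfur proves able to move the number: a 9.3-fold lower number from compound 3 to compound 4 (0.97 log units; beyond the scatter) is the first step beyond the scatter, whereas every earlier replacement of the group on the saturated chain carbon bound to the sulfur stayed within it. The separation also holds against the other two compounds, with a 5.4-fold lower number from compound 2 to compound 4 (0.73 log units; beyond the scatter) and a 9.2-fold lower number from compound 1 to compound 4 (0.96 log units; beyond the scatter) both setting compound 4 apart from the earlier members. This single change brings in the nitrogen with its hydrogen-bond donor and exchanges fluorine for chlorine together, and no measured information on why the number moves is at hand.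

Still open, going by these compounds, is which part of the change carries the step: (4-fluorophenyl)amino on the same carbonyl carbon and (4-chlorophenyl)carbonyl on the saturated chain carbon bound to the sulfur would pull the nitrogen and the chlorine apart. Also open, on these data alone, is whether a longer chain on the sulfur, or a carboxylic acid or a plain amine in place of the (4-chlorophenyl)carbamoyl group, would keep compound 4's position.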